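From Cyclobutyl to 2-Methylphenyl on a Shared Core

The source may hold more compounds than are shown below. What is called first, only, known or untested is meant among the compounds shown, and "the series" means these compounds.

Of the compounds shown here, three built on a shared core have been tested in an in vitro functional assay on cells for agonist activity at Bombesin receptor subtype-3 (Homo sapiens), read by luminescence and calcium flux; a lower number here means that less compound is needed, a higher number that more compound is needed for the effect. Compound 1 `CCCCc1cnc(Cc2ccc(-c3ccccc3C(=O)O)cc2)[nH]1` gives only > 10000 nM, which is a limit of the assay rather than a number. Compound 2 `CCCCc1cnc(C(CCC)Cc2ccc(-c3ccccc3C(=O)O)cc2)[nH]1` gives 1180 nM. Compound 3 `O=C(O)c1ccccc1-c1ccc(CCc2ncc(CC3CCC3)[nH]2)cc1` gives 588 nM; the gap to compound 2 lies within the usual scatter, so the two sit together rather than in any order. The value of compound 1 is a limit and cannot be placed against them. Compound 4 `Cc1ccccc1Cc1cnc(CCc2ccc(-c3ccccc3C(=O)O)cc2)[nH]1` has not yet been measured. It differs from compound 3 in one place: 2-methylphenyl in place of cyclobutyl on a saturated chain carbon bound to an aromatic carbon. Within the data shown here, no pair of measured compounds shows this change on its own, so there is no measured step to lean on. The estimate for compound 4 starts from compound 3 at 588 nM. The step of a 1.3-fold lower number from compound 3 to compound 4 (0.12 log units; within the scatter) is expected to be small, close to the scatter, without a clear direction. Compound 4 is therefore estimated at 450 nM, with a plausible range from 120 nM to 2000 nM.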

Compound 4, half-maximal effective concentration: 127 nM
For compound 4 the middle estimate is 3.5-fold (0.55 log units) above the measured one; measured number inside the range.
By their numbers in this assay, from the lowest: compound 4; then compounds 3 and 2 (each within the scatter of the next). At a limit, above all of these: compound 1.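

In this assay, 2-methylphenyl in place of cyclobutyl on a saturated chain carbon bound to an aromatic carbon gives a 4.6-fold lower number from compound 3 to compound 4 (0.67 log units; beyond the scatter). Among these compounds, this is the first step here that rests on one change alone, and it shows that this position accepts a six-membered aromatic ring of carbon in place of a four-membered non-aromatic ring, with less compound needed for the effect. Nothing measured here accounts for the size of this step.

On these data alone, what remains open is whether the aromatic ring or its methyl carries the step; plain benzyl in place of 2-methylbenzyl would separate the two. A chain ending in an amine at this place would show whether the position also accepts a very different kind of group.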